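The compounds below may be only part of what the source reports. "The series", "measured", "known", "first", "only" and "open" are said of these compounds alone.

The two measured compounds share one core and differ only in the group on the ring nitrogen. Compound 1, `Nc1scc(CN2CCN(c3ccncc3)CC2)c1C(=O)c1ccc(Cl)cc1`, gives -8.3% in a functional assay on CHO cells with adenosine receptor A1 (Homo sapiens) as the target, read by cAMP accumulation and immunoassay, with a stated time of 6 min, tested at 1 uM; a lower number here means a stronger effect, a higher number a weaker effect of the compound at the concentration tested. Compound 2, `Nc1scc(CN2CCN(c3cc(F)ccc3F)CC2)c1C(=O)c1ccc(Cl)cc1`, gives -59% in this assay, the lowest of the two numbers shown; the step of a number 50.7 percentage points lower from compound 1 to compound 2 (beyond the scatter) separates it from compound 1. Compound 3, `Nc1scc(CN2CCN(c3ccc(F)c(Cl)c3)CC2)c1C(=O)c1ccc(Cl)cc1`, carries 3-chloro-4-fluorophenyl in place of 2,5-difluorophenyl on an amine nitrogen in a ring. Among the measured compounds shown here, the only measured step, the large one from compound 1 to compound 2, exchanged a pyridin-4-yl for a halogenated phenyl; the change to compound 3 keeps a halogenated phenyl and only rearranges the halogens, so that step bears on it weakly. For the measured compounds named here, no measured step tells how two such phenyls compare, so a small step, expected as a number 9 percentage points higher from compound 2 to compound 3 (within the scatter), within the usual scatter is the most that can be said. For compound 3 the estimate in this assay is therefore -50%, ranging from -80% to -15%.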

Compound 3, a percentage reported as activity, at one concentration (the size of the read-out at that concentration, not a potency): -60%
The estimate for compound 3 lay 10 percentage points above the measured number; the range from low to high includes it.
By their numbers in this assay, from the lowest: compounds 3 and 2 (each within the scatter of the next); then compound 1.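

On the amine nitrogen in the ring, the halogen pattern on the phenyl does not separate the two compounds in this assay: 3-chloro-4-fluorophenyl in place of 2,5-difluorophenyl gives a number 1 percentage points lower from compound 2 to compound 3 (within the scatter) and leaves the read-out where it stood. The large gap to pyridin-4-yl also appears with a second halogenated phenyl, as a number 51.7 percentage points lower from compound 1 to compound 3 (beyond the scatter) shows, so it is not tied to one arrangement of the halogens. No evidence is available to explain these numbers.

From the compounds shown here alone, whether a plain phenyl without halogen, or a phenyl bearing a methoxy group or a nitrile, would fall with the two halogenated phenyls or with pyridin-4-yl stays open. So does the outcome for pyridin-3-yl or pyridin-2-yl, where the ring nitrogen stands elsewhere.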